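Aryl thiourea acyl series: amine-ring chloro in place of methyl

The compounds below may be only part of what the source reports. "The series", "measured", "known", "first", "only" and "open" are said of these compounds alone.

Measured so far in a functional assay on A549 cells (Homo sapiens) for inhibition, read by CCK-8 assay, with a stated time of 48 h; on this read-out higher numbers stand for weaker inhibition and lower numbers for stronger inhibition:
compound 1 `Cc1ccc(NC(=S)NC(=O)c2cn(-c3ccccc3)nc2-c2ccc(F)cc2)cc1` gives 2080 nM
compound 2 `Cc1ccc(NC(=S)NC(=O)c2cn(-c3ccccc3)nc2-c2ccc(Cl)cc2)cc1` gives 2690 nM

Among the measured compounds shown here, compound 1 gives the number that compound 2 matches within the scatter, the one measured step, a 1.3-fold higher number from compound 1 to compound 2 (0.11 log units; within the scatter), changing only the halogen on the other aryl ring. Compound 3 `O=C(NC(=S)Nc1ccc(Cl)cc1)c1cn(-c2ccccc2)nc1-c1ccc(F)cc1` differs from compound 1 elsewhere: chloro in place of methyl on an aromatic carbon. For the measured compounds named here, no measured step alters this ring of the shared core, so nothing speaks directly to the change; the only step on record, from compound 1 to compound 2, shows that a small exchange on an aryl carbon left this assay unmoved beyond the scatter. On that basis no step beyond the scatter is expected from compound 1 to compound 3, in either direction. Compound 3 is estimated to give 2500 nM in this assay, within a range of 1000 nM to 6500 nM, which is the step of a 1.2-fold higher number from compound 1 to compound 3 (0.08 log units; within the scatter).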

Compound 3, half-maximal inhibitory concentration: 2990 nM
Compound 3: the middle estimate sits 1.2-fold (0.08 log units) below what was measured; the measured number falls inside the stated range.
By their numbers in this assay, from the lowest: compounds 1, 2 and 3 (each within the scatter of the next).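

In this assay, chloro in place of methyl at the position para to a large group gives a 1.4-fold higher number from compound 1 to compound 3 (0.16 log units; within the scatter), so this ring now has one measured exchange, and the read-out does not separate the two groups there. With the halogen exchange on the other aryl ring, a 1.3-fold higher number from compound 1 to compound 2 (0.11 log units; within the scatter), this makes two single-place exchanges on aromatic carbons that stay within the scatter, a pattern that covers only compound 1, compound 2 and compound 3, with none of them against it. No measurement at hand offers an explanation for this flat result.

From the compounds shown here alone, whether this position responds to any change remains open, since one pair of groups cannot show what an amine, a carboxylic acid or a methoxy group would do there. Going by these compounds, it is also open whether the unsubstituted phenyl would stay within the scatter of compound 1.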